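Amino for Nitro on Two Sulfone Cores: Growth Inhibition

The source may hold more compounds than are shown below. What is called first, only, known or untested is meant among the compounds shown, and "the series" means these compounds.

The measurements come from a functional assay on MCF7 cells (Homo sapiens) for cytotoxicity, read by MTT assay, with a stated time of 72 h; a lower number here means a stronger inhibitor of growth, a higher number a weaker inhibitor of growth. Compound 1 has the structure `COc1cc(/C=C/S(=O)(=O)Cc2ccc(OC)c([N+](=O)[O-])c2)cc(OC)c1`. In this assay compound 1 reaches only the limit of the measurement, > 30000 nM, and no number. Compound 2 has the structure `COc1ccc(CS(=O)(=O)CC(=O)Nc2ccccc2)cc1[N+](=O)[O-]`; in this assay compound 2 likewise reaches only the limit, > 30000 nM. Compound 3, with the structure `COc1ccc(CS(=O)(=O)CC(=O)Nc2ccccc2)cc1N`, also reaches only the limit in this assay, > 30000 nM. The difference between the cores of compound 1 and compound 2 is not broken down here.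

Compound 3 differs from compound 2 by a single change: amino in place of nitro on an aromatic carbon. The size of this step is a step that the two limits leave unreadable from compound 2 to compound 3, so nothing can be read from it, because of the limit of > 30000 nM in this assay, at which 3 of the 3 values shown sit.

Compound 4, with the structure `COc1cc(/C=C/S(=O)(=O)Cc2ccc(OC)c(N)c2)cc(OC)c1`, is not yet measured. It differs from compound 1 by the same change: amino in place of nitro on an aromatic carbon. The step expected for compound 4 is a step that the limit leaves unreadable from compound 1 to compound 4, and this expectation rests on the step that the two limits leave unreadable from compound 2 to compound 3, which left the second core at the limit on both sides. Since compound 1 also sits at the limit, compound 4 is expected to give 40000 nM, most likely again as a limit rather than a number, with a range from 12000 nM to 150000 nM.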

Compound 4, concentration for 50% growth inhibition: 490 nM
The estimate for compound 4 lay 82-fold (1.91 log units) above the measured number, and the stated range ends above it.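

In this assay, amino in place of nitro on an aromatic carbon gives an at least 61-fold lower number from compound 1 to compound 4 (1.78 log units; beyond the scatter), so on the core of compound 1 this single change makes a large difference to growth inhibition. On the core of compound 2, the same change leaves compound 3 still without a number, so that step cannot be read, and a small gain and no gain at all would look alike there. The result therefore shows that the change can work on one core and that its effect does not reach a readable value on the other, but it does not show why the cores differ, nor whether the change would bring a similar gain on any further core, and the size of the step on the second core stays hidden for this reason: the limit of > 30000 nM in this assay, at which 3 of the 4 values shown sit.

The compounds shown leave open whether the gain needs a free amino group, which a methylamino group, an acetamide or a hydroxyl group on that same aromatic carbon would help to test. Also open, going by these compounds, is which part of the core of compound 1 allows the gain, as compound 4 and compound 3 differ in more than one place and cannot be compared directly.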